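Aniline ring swap on the shared core: compound 1 to compound 4

The compounds below may be only part of what the source reports. "The series", "measured", "known", "first", "only" and "open" are said of these compounds alone.

Compound 1 `CCn1c(=O)/c(=C2\Sc3ccccc3N2C)s/c1=C\c1ccncc1Nc1cc(C)ccc1C` carries a 2,5-dimethylphenyl on the aniline nitrogen of the shared core. In a functional assay on PC-3 cells (Homo sapiens) for inhibition (a higher number here means a weaker inhibitor, a lower number a stronger inhibitor), compound 1 gives 2000 nM, the highest of the three numbers recorded. Compound 2 `CCn1c(=O)/c(=C2\Sc3ccc(C)cc3N2C)s/c1=C\c1ccncc1Nc1ccccc1Cl` gives 500 nM and compound 3 `CCn1c(=O)/c(=C2\Sc3ccc(OC)cc3N2C)s/c1=C\c1ccncc1Nc1ccccc1C` gives 370 nM, both beyond the scatter from compound 1; neither differs from compound 1 in one place only, so no single change can be separated out. Compound 4 `CCn1c(=O)/c(=C2\Sc3ccccc3N2C)s/c1=C\c1ccncc1Nc1cc(F)ccc1F` differs from compound 1 by 2,5-difluorophenyl in place of 2,5-dimethylphenyl on a nitrogen on an aromatic ring. Among the measured compounds shown here, no measured pair shows this kind of exchange, so the step from compound 1 to compound 4 is expected to stay small, with direction uncertain, a 1.3-fold lower number from compound 1 to compound 4 (0.12 log units; within the scatter). Compound 4 is estimated at 1500 nM, within 500 nM to 5000 nM.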

Compound 4, half-maximal inhibitory concentration: 1200 nM
Compound 4: the middle estimate sits 1.3-fold (0.10 log units) above what was measured; the measured number falls inside the stated range.
By their numbers in this assay, from the lowest: compounds 3 and 2 (each within the scatter of the next); then compounds 4 and 1 (each within the scatter of the next).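

In this assay, among the compounds shown here, the exchange of 2,5-dimethylphenyl for 2,5-difluorophenyl on a nitrogen on an aromatic ring gives a 1.7-fold lower number from compound 1 to compound 4 (0.22 log units; within the scatter) and is the first change that can be read on its own. At this position, these two groups cannot be told apart in this read-out. Nothing on hand offers an explanation for this result.

Open, on these data alone, is how a phenyl carrying a carboxylic acid or an amine would read on this nitrogen. Also open, as far as these compounds go, is whether the same exchange would read alike on the cores of compound 2 and compound 3, which carry methyl and methoxy.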